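A few compounds are considered here, and "the series" means these few. Any claim that something is new, unique, unknown or untested is made for them only; others in the source may bear on it.

Measured compounds:
- compound 1 `Cc1cc(C)c(NC(=O)N(Cc2cc(-c3ccccc3)cs2)C2CCCCCC2)c(C)c1`: 36 nM
- compound 2 `O=C(Nc1c(F)cc(F)cc1F)N(Cc1ccc(-c2ccccn2)cc1)C1CCCCCC1`: 25 nM
- compound 3 `Cc1cc(C)c(NC(=O)N(Cc2ccc(-c3cccnc3)cc2)C2CCCCCC2)c(C)c1`: 130 nM

All three were run in an assay on microsomes from intestine for inhibition of acyl-CoA:cholesterol acyltransferase (Oryctolagus cuniculus); on this read-out higher numbers stand for weaker inhibition and lower numbers for stronger inhibition. Compound 3 carries the highest number of the three; its gaps to compound 1 and to compound 2 both lie beyond the usual scatter, so on these numbers compound 3 is the weakest inhibitor of the set. Compound 1 and compound 2 differ from compound 3 in more than one place, so no single-change step can be read off between any pair of the measured compounds.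

The next compound, compound 4 `Cc1cc(C)c(NC(=O)N(Cc2ccc(-n3ccnn3)cc2)C2CCCCCC2)c(C)c1`, differs from compound 3 in one place: 1H-1,2,3-triazol-1-yl in place of pyridin-3-yl on an aromatic carbon. Among the compounds with values here, no measured pair shows this change or anything close to it, so the size and direction of the step cannot be taken from the data; it rests only on the shared core of compound 3 and the value of compound 3.

Given that, the step from compound 3 to compound 4 is expected to be small, at most a little toward a higher number, a 1.5-fold higher number from compound 3 to compound 4 (0.19 log units; within the scatter). In this assay compound 4 is estimated at 200 nM, with a range from 60 nM to 700 nM.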

Compound 4, half-maximal inhibitory concentration: 42 nM
Compound 4: middle estimate off by 4.8-fold (0.68 log units), on the high side, and the stated range ends above it.
By their numbers in this assay, from the lowest: compounds 2, 1 and 4 (each within the scatter of the next); then compound 3.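

In this assay, within the data shown here, 1H-1,2,3-triazol-1-yl in place of pyridin-3-yl on an aromatic carbon, para to a large group, gives a 3.1-fold lower number from compound 3 to compound 4 (0.49 log units; beyond the scatter), the first single-change step and one that lies beyond the scatter. It shows that this position responds to the identity of the aromatic ring it carries, and that a five-membered aromatic ring with 3 hetero atoms is accepted here with stronger inhibition than a six-membered aromatic ring with 1 hetero atom. Nothing at hand accounts for the step, so it stands as an observation on this one pair, without an explanation.

Ring size, heavy-atom count and the number of ring nitrogens and hydrogen-bond acceptors all change together in this one swap, so their contributions cannot be separated on these compounds. Also open, going by these compounds, are how 1H-pyrazol-1-yl, 1H-1,2,4-triazol-1-yl or a carboxylic acid would fare at this position, and whether the triazole swap would give a step of similar size on the core of compound 2.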